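Changing the sulfonyl aryl group of compound 2

A few compounds are considered here, and "the series" means these few. Any claim that something is new, unique, unknown or untested is made for them only; others in the source may bear on it.

Measured so far:
In a functional assay on PC-3 cells (Homo sapiens) for cytotoxicity, read by luminescence (on this read-out higher numbers stand for weaker inhibition and lower numbers for stronger inhibition), compound 1 `C=C(CC)C(=O)c1ccc(OCC(=O)N2CCN(S(=O)(=O)c3ccc(OC)cc3)CC2)c(Cl)c1Cl` gives 24 nM.
In this assay compound 2 `C=C(CC)C(=O)c1ccc(OCC(=O)NC2CCN(S(=O)(=O)c3ccc(OC)cc3)CC2)c(Cl)c1Cl` gives 112 nM.

Of the two numbers measured, compound 2 stands at the highest, meaning weaker inhibition; its nearest neighbour, compound 1, shows a lower number, and the gap between them lies beyond the usual scatter. Compound 3 `C=C(CC)C(=O)c1ccc(OCC(=O)NC2CCN(S(=O)(=O)c3cc(Cl)ccc3OC)CC2)c(Cl)c1Cl` is not yet measured. It differs from compound 2 in one place: 5-chloro-2-methoxyphenyl in place of 4-methoxyphenyl on a sulfonyl sulfur, with a chlorine added to the ring and the methoxy group moved. No comparable change has been measured among the two known compounds, so there is nothing to show which direction such a change takes. The expectation is therefore a step of about a 1.1-fold higher number from compound 2 to compound 3 (0.03 log units; within the scatter), that is, no change beyond the scatter, with the direction open. For compound 3 the estimated value is 120 nM, expected to fall between 40 nM and 400 nM.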

Compound 3, half-maximal inhibitory concentration: 76 nM
Compound 3: the middle estimate sits 1.6-fold (0.20 log units) above what was measured; measured number inside the range.
By their numbers in this assay, from the lowest: compound 1; then compounds 3 and 2 (each within the scatter of the next).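

Swapping 4-methoxyphenyl for 5-chloro-2-methoxyphenyl on the sulfonyl sulfur gives, in this assay, a 1.5-fold lower number from compound 2 to compound 3 (0.17 log units; within the scatter) and so stays within the usual scatter. Going by these compounds alone, this is the first view of this position, as compound 1 and compound 2 carry the same sulfonyl aryl group, and it shows that adding a chlorine and moving the methoxy group together leave the number without a clear shift. Nothing available bears on why these two compounds read so alike.

Because the chlorine and the moved methoxy group arrive together, the compounds shown cannot separate what each does alone. Also open, from the compounds shown here alone, are very different groups on the ring, such as an amine or a carboxylic acid, and whether the same swap would read alike on the core of compound 1.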